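The source may hold more compounds than are shown below. What is called first, only, known or untested is meant among the compounds shown, and "the series" means these compounds.

Measured compounds:
compound 1 `CCN(CCCCCCOc1ccc(C(=O)/C=C/c2ccc(N(C)C)cc2)c(O)c1)Cc1ccccc1N(C)C` — 2100 nM
compound 2 `CCN(CCCOc1ccc(C(=O)/C=C/c2ccc(N(C)C)cc2)c(O)c1)Cc1ccccc1N(C)C` — 3200 nM
compound 3 `CCN(CCCOc1ccc(C(=O)/C=C/c2ccc(N(C)C)cc2)c(O)c1)Cc1ccc(N(C)C)cc1` — 13700 nM

All three were tested in an assay on isolated protein for inhibition of Amine oxidase [flavin-containing] B (Homo sapiens); a lower number here means a stronger inhibitor, a higher number a weaker inhibitor. Compound 1 gives 2100 nM, and compound 2 gives 3200 nM; these two numbers lie within the usual scatter of each other, so no order between them can be claimed. The difference between the cores of compound 1 and compound 2 is not broken down here. Compound 3 gives 13700 nM in this assay.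

Compound 2 and compound 3 differ in one place: 4-(dimethylamino)phenyl in place of 2-(dimethylamino)phenyl on a saturated chain carbon bound to an amine nitrogen. This change made a 4.3-fold higher number from compound 2 to compound 3 (0.63 log units; beyond the scatter), a step that lies beyond the scatter and weakens inhibition.

Compound 4 `CCN(CCCCCCOc1ccc(C(=O)/C=C/c2ccc(N(C)C)cc2)c(O)c1)Cc1ccc(N(C)C)cc1` has not yet been measured in this assay. It relates to compound 1 the way compound 3 relates to compound 2: 4-(dimethylamino)phenyl in place of 2-(dimethylamino)phenyl on a saturated chain carbon bound to an amine nitrogen. The place is the same in both pairs, so this is the same change made on a different core. Only one earlier example of this change exists, so the expectation rests on a single step and stays uncertain; no compound shown speaks against it.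

Compound 4 is therefore expected to be a weaker inhibitor than compound 1, with an estimated step of a 4.3-fold higher number from compound 1 to compound 4 (0.63 log units; beyond the scatter), because the same change gave a 4.3-fold higher number from compound 2 to compound 3 (0.63 log units; beyond the scatter). The estimated value for compound 4 in this assay is 9000 nM, expected to fall between 4000 nM and 20000 nM.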

Compound 4, half-maximal inhibitory concentration: 2300 nM
Beside the measured number, compound 4's estimate is 3.9-fold (0.59 log units) above it, and the stated range ends above it.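

In this assay, putting 4-(dimethylamino)phenyl in place of 2-(dimethylamino)phenyl gave a 1.1-fold higher number from compound 1 to compound 4 (0.04 log units; within the scatter), so on this longer-chained core the change has no effect that can be told from the scatter. The change therefore did not carry over with the same size from one core to the other, and the step seen earlier is not a reliable guide to this one: the same change on two cores in this assay, a 4.3-fold higher number (0.63 log units; beyond the scatter) from compound 2 to compound 3 and a 1.1-fold higher number (0.04 log units; within the scatter) from compound 1 to compound 4, 3.9-fold (0.59 log units) apart, beyond the scatter of two such steps. This shows that, for these two pairs, the outcome of the change depends on the core that carries it, but it does not show which feature of the cores is responsible, why the two steps differ, or how the change would behave on any third core.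

The compounds shown leave open whether the weakening seen on the shorter-chained core appears gradually or suddenly as the chain grows, since only two chain lengths are present and a chain of intermediate length, or a longer chain, would be needed to tell. They also leave open whether the same pattern would hold with a different amine on the benzyl ring, such as a pyrrolidine in place of the dimethylamino group.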